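Dropping a Branch from a Folate Enzyme Inhibitor

The compounds below may be only part of what the source reports. "The series", "measured", "known", "first", "only" and "open" are said of these compounds alone.

This piece follows one change made to compound 1 `Cc1c(NC(=O)C(Sc2ccc3ccccc3c2)C(C)C)ccc2nc(N)nc(N)c12` and asks what it may do in an assay for inhibition of Dihydrofolate reductase (Homo sapiens); a higher number here means a more potent compound, by a factor of ten per unit of this negative logarithm, a lower number a less potent compound. Going by the values given here, compound 1 gives 7.68, the higher of the two numbers known here. Among the compounds with values here, its only neighbour is compound 2 `Cc1cccc2nc(N)nc(N)c12`, the shared core without any side chain, which in this assay gives 6.09, lower by a margin well beyond the scatter. These two values show only that the whole side chain adds a great deal; which part of it carries the gain is not known. Compound 3 `Cc1c(NC(=O)CSc2ccc3ccccc3c2)ccc2nc(N)nc(N)c12` is compound 1 with a single alteration: hydrogen in place of isopropyl on a saturated chain carbon bound to a carbonyl carbon and a sulfur. A modest drop is expected, estimated as a number 0.48 log units lower from compound 1 to compound 3 (beyond the scatter), since a branch is lost but the larger part of the side chain remains. For compound 3 the estimate in this assay is 7.2, with a range from 6.6 to 7.8.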

Compound 3, logarithm of the reciprocal of the active concentration, log(1/C): 8.27
Estimate against measurement, compound 3: 1.07 log units below; the measured number lies above the stated range.
By their numbers in this assay, from the lowest: compound 2; then compound 1; then compound 3.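

Placing hydrogen on the saturated chain carbon bound to a carbonyl carbon and a sulfur gives a number 0.59 log units higher from compound 1 to compound 3 (beyond the scatter) in this assay, so the isopropyl group is not needed for the high number of compound 1. At this position, the smaller of the two groups shown gives the higher number, and compound 3 keeps the rest of the side chain unchanged. Nothing available here accounts for this rise.

With only hydrogen and isopropyl shown at this carbon, two compounds cannot establish a trend with group size. A methyl or ethyl group might fall between them or outside them, and an amine or a carboxylic acid at the same carbon remains an open question in this assay, as does a longer chain.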